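Swapping octyl for phenyl beside the ynoate chain

A few compounds are considered here, and "the series" means these few. Any claim that something is new, unique, unknown or untested is made for them only; others in the source may bear on it.

Compound 1 `C#CCO/C=C/C(=O)OC` sits at a limit in a functional assay on HBL-100 cells (Homo sapiens) for antiproliferative activity, read by sulforhodamine B assay, with a stated time of 48 h; on this read-out lower numbers stand for stronger inhibition of growth and higher numbers for weaker inhibition of growth: it gives > 100000 nM, which is a bound of the assay rather than a number. Among the measured compounds shown here, compound 2 `CCCCCCCCCCC(C#CC(=O)OC)O/C=C/C(=O)OC` supplies the only number, giving 2200 nM in this assay. The single limit is the one shown for compound 1 (the limit of > 100000 nM in this assay, at which 1 of the 2 values shown sits). Compound 3 `COC(=O)C#CC(CCc1ccccc1)O/C=C/C(=O)OC` carries the change (phenyl in place of octyl on a saturated chain carbon, three bonds along the chain from an oxygen on an unsaturated carbon and a triple-bonded carbon). For the measured compounds named here, no comparable step has been measured, so the change from compound 2 to compound 3 is expected to stay close to the scatter, with weakening slightly more likely than strengthening, as a 1.6-fold higher number from compound 2 to compound 3 (0.20 log units; within the scatter). Compound 3 is estimated at 3500 nM, within 900 nM to 14000 nM.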

Compound 3, concentration for 50% growth inhibition: 2600 nM
Compound 3: the middle estimate sits 1.3-fold (0.13 log units) above what was measured; the measured number falls inside the stated range.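

In this assay the swap gives a 1.2-fold higher number from compound 2 to compound 3 (0.07 log units; within the scatter), so at this saturated chain carbon, phenyl takes the place of octyl without moving growth inhibition beyond the scatter. Among the compounds shown here, this is the first step that can be read at this position, and it shows that an aromatic ring of carbon only is tolerated there as well as an open chain. Nothing measured here bears on a reason for this result. Still open, going by these compounds, is whether an amine, a carboxylic acid or a much shorter chain at the same place would hold the number. On these data alone, whether a pyridine ring would do so is equally open.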